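The source may report more compounds than this note shows. Statements on the series, on what has been measured and on what is new or still open speak of the compounds shown alone.

Three compounds have so far been measured in a functional assay on OVCAR-3 cells (Homo sapiens) for cytotoxicity, read by sulforhodamine B assay, with a stated time of 48 h, tested at 0.1 uM; a lower number here means a stronger effect, a higher number a weaker effect of the compound at the concentration tested:

compound 1, `COc1cc(-c2cc(/C=C/C(=O)c3ccc(N)cc3)[nH]n2)cc(OC)c1OC`: 110%
compound 2, `COc1cc(-c2cc(/C=C/C(=O)c3ccc(Cl)c(Cl)c3)[nH]n2)cc(OC)c1OC`: 105%
compound 3, `COc1ccc(C(=O)/C=C/c2cc(-c3cc(OC)c(OC)c(OC)c3)n[nH]2)cc1OC`: 100%

Compound 3 carries the lowest of the three numbers, but this places it nowhere in particular: the step of a number 5 percentage points lower from compound 2 to compound 3 (within the scatter) and the step of a number 10 percentage points lower from compound 1 to compound 3 (within the scatter) both lie within the scatter, as does a number 5 percentage points lower from compound 1 to compound 2 (within the scatter). The three compounds, which differ only in the aryl group on the carbonyl carbon, are therefore indistinguishable in this assay.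

Compound 4, `COc1ccc(C(=O)/C=C/c2cc(-c3cc(OC)c(OC)c(OC)c3)n[nH]2)cc1`, is reached from compound 3 by a change on that same aryl group: hydrogen in place of methoxy on an aromatic carbon. The measured steps that bear on it are those that exchange the whole aryl group on the carbonyl carbon, and none of them moves the number beyond the scatter, whether a 4-aminophenyl, a 3,4-dichlorophenyl or a 3,4-dimethoxyphenyl sits there. Removing one methoxy from the 3,4-dimethoxyphenyl is a smaller change than any of those, so no step beyond the scatter is expected in this assay, in either direction. Compound 4 is accordingly estimated at 103%, within 90% to 116%, which means an expected step of a number 3 percentage points higher from compound 3 to compound 4 (within the scatter).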

Compound 4, a percentage reported as activity, at one concentration (the size of the read-out at that concentration, not a potency): 101%
Estimate against measurement, compound 4: 2 percentage points above, within the range that was stated.
By their numbers in this assay, from the lowest: compounds 3, 4, 2 and 1 (each within the scatter of the next).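

With hydrogen in place of methoxy on an aromatic carbon, ortho to a methoxy group and meta to a large group, this assay shows a number 1 percentage points higher from compound 3 to compound 4 (within the scatter) as its result, so the methoxy at this place can be exchanged for hydrogen without a step beyond the scatter. For the compounds shown here, this is the first comparison to change a single group on this aryl ring, whereas the earlier steps exchanged the whole ring, and the 4-methoxyphenyl compound also stays level with the other two, with a number 4 percentage points lower from compound 2 to compound 4 (within the scatter) as one step and a number 9 percentage points lower from compound 1 to compound 4 (within the scatter) as the other. Nothing measured here bears on why this exchange leaves the read-out within the scatter.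

The compounds shown leave open whether a different group at this place, such as a hydroxyl, an amine, a carboxylic acid or a longer alkoxy chain, would give a step beyond the scatter. They also leave open whether removing the remaining methoxy from the 4-methoxyphenyl group, to give an unsubstituted phenyl, would separate such a compound from the four shown here.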